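Working notes on the step from compound 2 to compound 4

The compounds below may be only part of what the source reports. "The series", "measured", "known", "first", "only" and "open" are said of these compounds alone.

Measured compounds:
- compound 1, `C=CCOc1c(C)c(C)c2c(c1C)CCC(C)(COc1cccc(/C=C3\SC(=O)NC3=O)c1)O2`: 92%
- compound 2, `CC(C)=CCOc1c(C)c(C)c2c(c1C)CCC(C)(COc1ccc(/C=C3\SC(=O)NC3=O)cc1F)O2`: 87%
- compound 3, `Cc1c(C)c2c(c(C)c1OC(=O)CCC(=O)O)CCC(C)(COc1ccc(/C=C3\SC(=O)NC3=O)cc1)O2`: 98%

All three were read in a functional assay on MCF7 cells (Homo sapiens), tested at 5 uM; on this read-out higher numbers stand for a weaker effect at the one concentration tested and lower numbers for a stronger effect. Compound 2 stands lowest of the three numbers shown; its nearest neighbour is compound 1, whose number lies within the usual scatter of it, so no order between these two can be drawn. Compound 3 lies beyond the scatter from compound 2, at the weak end of what this read-out shows. Among the compounds with values here, no pair among the three differs in a single place, so no single-step effect is known from measured compounds.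

Compound 4, `CCOc1cc(/C=C2\SC(=O)NC2=O)ccc1OCC1(C)CCc2c(C)c(OCC=C(C)C)c(C)c(C)c2O1`, has not yet been measured. It differs from compound 2 in one place: ethoxy in place of fluoro on an aromatic carbon. Within the data shown here, with no measured step of this kind available, the expectation rests on the narrow band that all three numbers occupy; the step is estimated as a number 3 percentage points higher from compound 2 to compound 4 (within the scatter), that is, none beyond the scatter. Compound 4 is accordingly expected to give 90%, within a range from 78% to 100%.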

Compound 4, a percentage reported as activity, at one concentration (the size of the read-out at that concentration, not a potency): 84%
Compound 4: the middle estimate sits 6 percentage points above what was measured; low and high end bracket the measured number.
By their numbers in this assay, from the lowest: compounds 4, 2, 1 and 3 (each within the scatter of the next, the first and the last beyond it).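

Within the data shown here, this is the first comparison that differs in one place. In this assay, ethoxy in place of fluoro on an aromatic carbon, ortho to a large group, gives a number 3 percentage points lower from compound 2 to compound 4 (within the scatter), so the read-out at this one concentration does not separate the two groups. This position therefore accepts ethoxy as well as fluoro without a change beyond the scatter, and no measurement shown bears on the reason.

On these data alone, whether an amine, a carboxylic acid or a longer alkoxy chain at this position would shift the number beyond the scatter remains open. Also open, as far as these compounds go, is whether the same swap reads alike when the rest of the molecule differs, as it does in compound 1 and compound 3.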